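The source may hold more compounds than are shown below. What is called first, only, known or untested is meant among the compounds shown, and "the series" means these compounds.

Measured compounds:
- compound 1 `COc1ccc(-c2nc(/N=C(\N)n3ccnc3)sc2-c2ccc(OC)cc2)cc1` — in a functional assay with Oryctolagus cuniculus as the target (on this read-out lower numbers stand for stronger inhibition and higher numbers for weaker inhibition), compound 1 reaches only the limit > 100 nM, a bound of the assay rather than a number.
- compound 2 `COc1ccc(-c2nc(CNC(=O)c3cccnc3)sc2-c2ccc(OC)cc2)cc1` — in this assay compound 2 gives 25 nM.
- compound 3 `CNC(=O)NCc1nc(-c2ccc(OC)cc2)c(-c2ccc(OC)cc2)s1` — in this assay compound 3 gives 22 nM.

Compound 3 holds the lowest of the two numbers, but its nearest neighbour compound 2 sits within the scatter, a 1.1-fold lower number from compound 2 to compound 3 (0.06 log units; within the scatter), so the two cannot be ranked. Both stand clearly apart from the limit of compound 1 (the limit of > 100 nM in this assay, at which 1 of the 3 values shown sits), seen in an at least 4.0-fold lower number from compound 1 to compound 2 (0.60 log units; beyond the scatter) and an at least 4.5-fold lower number from compound 1 to compound 3 (0.65 log units; beyond the scatter).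

Compound 4 `CCOC(=O)/C=C/c1nc(-c2ccc(OC)cc2)c(-c2ccc(OC)cc2)s1` is not yet measured. The change is 2-(ethoxycarbonyl)ethenyl in place of ((methylcarbamoyl)amino)methyl on an aromatic carbon. The measured steps all touch the same group on the shared core: swapping methylamino for pyridin-3-yl left the number unchanged, while replacing the ring-bearing group of compound 1 lowered it by at least a modest amount. The move to 2-(ethoxycarbonyl)ethenyl is a larger departure than the step from compound 2 to compound 3, so a modestly higher number for compound 4 is expected, a 2.7-fold higher number from compound 3 to compound 4 (0.44 log units; beyond the scatter), with the estimate 60 nM and a range from 20 nM to 300 nM.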

Compound 4, half-maximal inhibitory concentration: 20 nM
Estimate against measurement, compound 4: 3.0-fold (0.48 log units) above; measured number inside the range.
By their numbers in this assay, from the lowest: compounds 4, 3 and 2 (each within the scatter of the next). At a limit, above all of these: compound 1.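

In this assay, the aromatic carbon next to the ring nitrogen and the ring sulfur accepts 2-(ethoxycarbonyl)ethenyl, with 0 hydrogen-bond donors and no nitrogen, on a par with the nitrogen-containing groups of compound 3 and compound 2: a 1.1-fold lower number from compound 3 to compound 4 (0.04 log units; within the scatter) and a 1.3-fold lower number from compound 2 to compound 4 (0.10 log units; within the scatter). So a nitrogen in this group is not needed for a number in this range, and three quite different groups cannot be told apart here, while the group of compound 1 stays apart, with an at least 5.0-fold lower number from compound 1 to compound 4 (0.69 log units; beyond the scatter). Compound 1 gives only a limit, not a number: the limit of > 100 nM in this assay, at which 1 of the 4 values shown sits.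

As far as these compounds go, it remains open which part of 2-(ethoxycarbonyl)ethenyl matters, the double bond or the ester; the matching carboxylic acid or the saturated chain would address that. Also open, from the compounds shown here alone, is how a far smaller group, such as methyl or a plain amine, would read on this carbon.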